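A few compounds are considered here, and "the series" means these few. Any claim that something is new, unique, unknown or untested is made for them only; others in the source may bear on it.

The study concerns two measured compounds and one yet to be measured, all built on the same core. Compound 1 `O=C(/C=C\CCCCCCc1ccccc1)N1CCCCC1` was tested in a functional assay on PANC-1 cells (Homo sapiens) for cytotoxicity, read by WST assay, with a stated time of 24 h; on this read-out higher numbers stand for weaker inhibition and lower numbers for stronger inhibition. In this assay compound 1 gives only a limit, > 100000 nM. Compound 2 `O=C(CCCCCCCCc1ccccc1)N1CCCCC1` likewise returns only a limit in this assay, namely > 100000 nM. Both values sit at the limit of > 100000 nM in this assay, at which 2 of the 2 values shown sit, so compound 2 stands at the edge of what this assay reports, level with compound 1, and no position on a numerical scale can be given for it. Compound 3 `O=C(CCCCCCCCc1ccc(F)cc1)N1CCCCC1` differs from compound 2 in one place: fluoro in place of hydrogen on an aromatic carbon. Among the compounds with values here, no measured step between two compounds is available to guide the size of this change. The expected step from compound 2 to compound 3 is small, a step that the limit leaves unreadable from compound 2 to compound 3, with no direction beyond the scatter. Compound 3 is therefore estimated at 150000 nM in this assay, within a range from 70000 nM to 500000 nM, most likely again reported only as a limit.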

Compound 3, half-maximal inhibitory concentration: 99800 nM
Beside the measured number, compound 3's estimate is 1.5-fold (0.18 log units) above it; low and high end bracket the measured number.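

In this assay compound 3 is the first compound shown to give a number rather than a limit, so the phenyl to 4-fluorophenyl change yields a value that can be read on this scale. The step reads as a number no higher from compound 2 to compound 3 (the limit leaves the size open), so only its direction can be stated, and whether it lies beyond the usual scatter cannot be read. Compound 3 therefore gives a first numerical anchor for the series, while the other values remain at the edge of the assay: the limit of > 100000 nM in this assay, at which 2 of the 3 values shown sit.

Going by these compounds, it remains open whether chloro or methoxy in place of the fluoro on the same aromatic carbon would give a lower or a higher number. On these data alone, it is equally open how a longer chain, or an amine in place of the piperidine-free end of the chain, would read in this assay.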